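Fluoro to Chloro on the Anilino Ring

A few compounds are considered here, and "the series" means these few. Any claim that something is new, unique, unknown or untested is made for them only; others in the source may bear on it.

Compound 2 `O=C(C1=C(Nc2ccc(F)cc2)C(=O)N(CCCn2ccnc2)C1c1ccc(Br)cc1)c1ccccc1` and compound 1 `O=C(C1=C(Nc2ccccc2)C(=O)N(CCCn2ccnc2)C1c1ccc(Br)cc1)c1ccccc1` stand within the scatter of each other in a functional assay on U2OS cells (Homo sapiens) for antiproliferative activity, read by MTT assay, with a stated time of 72 h; a lower number here means a stronger inhibitor, a higher number a weaker inhibitor: compound 2 gives 30000 nM, and compound 1 gives 25700 nM in this assay, the step of a 1.2-fold higher number from compound 1 to compound 2 (0.07 log units; within the scatter) being too small to order them. Compound 3 `O=C(C1=C(Nc2ccc(Cl)cc2)C(=O)N(CCCn2ccnc2)C1c1ccc(Br)cc1)c1ccccc1` differs from compound 2 by chloro in place of fluoro on an aromatic carbon. The only step shown at this aromatic carbon, hydrogen to fluoro, changed nothing beyond the scatter, so the step of no change at the digits printed from compound 2 to compound 3 (within the scatter) is expected to be likewise small in this assay. Compound 3 is therefore estimated at 30000 nM in this assay, with a range from 14000 nM to 65000 nM.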

Compound 3, half-maximal inhibitory concentration: 22800 nM
Beside the measured number, compound 3's estimate is 1.3-fold (0.12 log units) above it, and the stated range covers the measured number.
By their numbers in this assay, from the lowest: compounds 3, 1 and 2 (each within the scatter of the next).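

In this assay, chloro at this aromatic carbon, para to a large group, stays within the scatter of both fluoro (a 1.3-fold lower number from compound 2 to compound 3 (0.12 log units; within the scatter)) and hydrogen (a 1.1-fold lower number from compound 1 to compound 3 (0.05 log units; within the scatter)). The position has now taken two different halogens, and neither step separates the compounds, so hydrogen, fluoro and chloro cannot be ordered here. From the compounds shown here alone, whether a methoxy group, an amine or a carboxylic acid at this carbon would move the number beyond the scatter remains open, as does the effect of a change elsewhere on the shared core. No evidence is available to account for this result.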